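The source may report more compounds than this note shows. Statements on the series, on what has been measured and on what is new or still open speak of the compounds shown alone.

Compound 1, `Cc1nc(NCC(C)C)nc(N[C@@H]2C[C@H](CO)[C@@H](O)[C@H]2O)c1-c1nc2ccccc2s1`, and compound 2, `Cc1nc(NCCOC(C)C)nc(N[C@@H]2C[C@H](CO)[C@@H](O)[C@H]2O)c1-c1nc2ccccc2s1`, are the two measured compounds.
- In an ADME assay on cells (Homo sapiens) for cytotoxicity, read by polymerase chain reaction, with a stated time of 3 days (a higher number here means that more compound is tolerated, a lower number that less compound is tolerated), compound 1 gives 10000 nM.
- In this assay compound 2 gives 8000 nM.

Compound 2 holds the lower of the two numbers, yet the gap between the two is only a 1.3-fold lower number from compound 1 to compound 2 (0.10 log units; within the scatter), so on these data the two compounds cannot be told apart. Compound 3, `Cc1nc(NCc2nccs2)nc(N[C@@H]2C[C@H](CO)[C@@H](O)[C@H]2O)c1-c1nc2ccccc2s1`, has not been measured. It differs from compound 2 by 1,3-thiazol-2-yl in place of isopropoxymethyl on a saturated chain carbon bound to a nitrogen on an aromatic ring. Within the data shown here, only one measured step touches the same place on the molecule, the step from compound 1 to compound 2, and that step stayed inside the scatter. Among the measured compounds shown here, no measured compound carries a ring at this place, so the data give no hint of a shift in either direction for such a group. Compound 3 is therefore expected to move by about no change at the digits printed from compound 2 to compound 3 (within the scatter) in this assay. The estimate for compound 3 in this assay is 8000 nM, with a range from 3000 nM to 20000 nM.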

Compound 3, half-maximal cytotoxic concentration: 23000 nM
For compound 3 the middle estimate is 2.9-fold (0.46 log units) below the measured one; the measured number lies above the stated range.
By their numbers in this assay, from the lowest: compounds 2 and 1 (each within the scatter of the next); then compound 3.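

Among these compounds, until now, the only measured change at this place, on a saturated chain carbon bound to a nitrogen on an aromatic ring, had stayed within the scatter, so the position could have seemed indifferent to what sits there. In this assay, the 1,3-thiazol-2-yl group shows otherwise, with a 2.9-fold higher number from compound 2 to compound 3 (0.46 log units; beyond the scatter) and, against the other earlier compound, a 2.3-fold higher number from compound 1 to compound 3 (0.36 log units; beyond the scatter): both steps are modest, but both point the same way, towards more compound being tolerated. So this place can move the number, and an aromatic ring here gives a higher reading than either the isopropoxymethyl or the isopropyl group, although nothing shown explains why.

With a single ring at this place, the compounds shown leave open whether the shift belongs to aromatic rings in general or to 1,3-thiazol-2-yl alone, and a phenyl or a pyridin-2-yl group in the same place would help separate those two readings. They also leave open how an amine or a carboxylic acid at the end of this chain would read in this assay.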